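Longer Carbamate Chain on a Selenocyanate Anilide

A few compounds are considered here, and "the series" means these few. Any claim that something is new, unique, unknown or untested is made for them only; others in the source may bear on it.

Measured so far:
Compound 1 `C=CCOC(=O)Nc1ccc([Se]C#N)cc1` gives 68600 nM in a functional assay on CCRF-CEM cells (Homo sapiens) for cytotoxicity, read by MTT assay, with a stated time of 72 h; a lower number here means that less compound is tolerated, a higher number that more compound is tolerated.
Compound 2 `O=C(Nc1ccc([Se][Se]c2ccc(NC(=O)OCc3ccc([N+](=O)[O-])cc3)cc2)cc1)OCc1ccc([N+](=O)[O-])cc1` gives 68100 nM in this assay.

Compound 1 holds the higher of the two numbers, yet the gap to compound 2 lies within the scatter, so the two cannot be told apart on these data. Compound 3 `CCCCCCOC(=O)Nc1ccc([Se]C#N)cc1` has not yet been measured. It differs from compound 1 in a single place: pentyl in place of vinyl on a saturated chain carbon bound to an oxygen next to a carbonyl group. For the measured compounds named here, no measured pair shows the effect of lengthening this chain, so there is nothing to lean on except compound 1 itself, which gives 68600 nM. Without such a step, the expectation is a modest move toward less compound being tolerated, and it is estimated that the change from compound 1 to compound 3 amounts to a 1.7-fold lower number from compound 1 to compound 3 (0.23 log units; within the scatter). Compound 3 is therefore expected to give about 40000 nM, with a range from 15000 nM to 110000 nM.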

Compound 3, concentration lethal to 50% of the cells: 72700 nM
Compound 3: the middle estimate sits 1.8-fold (0.26 log units) below what was measured, within the range that was stated.
By their numbers in this assay, from the lowest: compounds 2, 1 and 3 (each within the scatter of the next).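

Replacing vinyl with pentyl on a saturated chain carbon bound to an oxygen next to a carbonyl group gives a 1.1-fold higher number from compound 1 to compound 3 (0.03 log units; within the scatter), so this assay cannot tell these two compounds apart. For the compounds shown here, this is the first single-place comparison, and it shows that this allyl to hexyl difference, which adds carbons and removes the double bond outside aromatic rings, produces no readable step at this position. No available evidence explains this result.

A single pair cannot show whether the same holds for other groups at this position. A longer chain such as dodecyl, or a chain ending in an amine or a carboxylic acid, might give a different result, and the compounds shown leave this open.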